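Carbamate chain variation on the selenocyanate core

The source may report more compounds than this note shows. Statements on the series, on what has been measured and on what is new or still open speak of the compounds shown alone.

Three carbamates on a shared core have been measured in a functional assay on MCF7 cells (Homo sapiens) for cytotoxicity, read by MTT assay, with a stated time of 72 h; a lower number here means a stronger inhibitor of growth, a higher number a weaker inhibitor of growth. Compound 3 `CCOC(=O)Nc1ccc([Se]C#N)cc1` gives 36700 nM. Compound 1 `C=CCOC(=O)Nc1ccc([Se]C#N)cc1` gives 43100 nM, and compound 2 `N#C[Se]c1ccc(NC(=O)OCc2ccc([N+](=O)[O-])cc2)cc1` gives 40700 nM. Compound 3 carries the lowest of the three numbers, but its gaps to compound 2 and to compound 1 are both within the scatter, so no ordering among the three can be claimed.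

The next compound, compound 4 `N#C[Se]c1ccc(NC(=O)OCc2ccccc2)cc1`, differs from compound 3 by phenyl in place of methyl on a saturated chain carbon bound to an oxygen next to a carbonyl group. Among the measured compounds shown here, the only measured step at this position is a 1.2-fold lower number from compound 1 to compound 3 (0.07 log units; within the scatter), which shows that exchanging one small chain group for another here left this assay essentially unchanged. For the measured compounds named here, no measured step replaces a small group with a ring at this place; compound 2, which carries a larger substituent on the same chain carbon, gives a value in the same narrow band as compounds 1 and 3. Taken together, the data give no ground to expect a shift beyond the scatter in this assay.

Compound 4 is therefore expected to give about 38000 nM, within a range of 18000 nM to 80000 nM, corresponding to an estimated step of a 1.0-fold higher number from compound 3 to compound 4 (0.02 log units; within the scatter).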

Compound 4, concentration for total growth inhibition: 38800 nM
Compound 4: middle estimate off by 1.0-fold (0.01 log units), on the low side; measured number inside the range.
By their numbers in this assay, from the lowest: compounds 3, 4, 2 and 1 (each within the scatter of the next).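

Phenyl in place of methyl on a saturated chain carbon bound to an oxygen next to a carbonyl group puts a six-membered aromatic ring of carbon only at this place for the first time, and in this assay the change reads as a 1.1-fold higher number from compound 3 to compound 4 (0.02 log units; within the scatter) and stays within the scatter. Set against the vinyl compound, the same ring gives a 1.1-fold lower number from compound 1 to compound 4 (0.05 log units; within the scatter) and again no separation, while hydrogen in place of nitro on an aromatic carbon gives a 1.0-fold lower number from compound 2 to compound 4 (0.02 log units; within the scatter) and shows that the nitro group on this ring makes no readable difference, so the flat band now spans small chain groups and both aromatic variants. Nothing on hand accounts for this flat response.

Still open, from the compounds shown here alone, is whether any group at this chain carbon can move the number beyond the scatter, for example an amine, a carboxylic acid or a longer chain in place of phenyl. Going by these compounds, all four compounds keep the shared core unchanged, so the effect of a change in the core also remains open.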